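Adding a hydroxy group to the pendant phenyl ring

A few compounds are considered here, and "the series" means these few. Any claim that something is new, unique, unknown or untested is made for them only; others in the source may bear on it.

Of the compounds shown here, two sharing one core have been measured in a functional assay on SGC-7901 cells (Homo sapiens) for antiproliferative activity, read by MTT assay, with a stated time of 72 h; on this read-out lower numbers stand for stronger inhibition and higher numbers for weaker inhibition. Compound 1 `COc1cc(-n2cnc3ccc(-c4ccccc4Cl)cc32)cc(OC)c1OC` gives only a limit of the assay in this assay, > 10000 nM. Among the measured compounds shown here, compound 2 `COc1cc(-n2cnc3ccc(-c4ccccc4)cc32)cc(OC)c1OC` gives 290 nM in this assay, the only value that is a number rather than a limit, so compound 2 is the sole fixed point in this set. For the measured compounds named here, the single step measured so far, an at least 34-fold lower number from compound 1 to compound 2 (1.53 log units; beyond the scatter), shows that the phenyl ring attached to the core tolerates a change at one of its carbons badly in one direction, the chloro-bearing compound 1 sitting at the limit of > 10000 nM in this assay, at which 1 of the 2 values shown sits, of this assay.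

Compound 3 `COc1cc(-n2cnc3ccc(-c4ccc(O)cc4)cc32)cc(OC)c1OC` has not been measured. It differs from compound 2 by hydroxy in place of hydrogen on an aromatic carbon. The measured step concerns a different group removed from the same ring, so it bears on this change only loosely and gives no direct guide to a hydroxy entering para to a large group. The step from compound 2 to compound 3 is therefore expected to be modest, a 1.6-fold higher number from compound 2 to compound 3 (0.19 log units; within the scatter), with a small move toward a higher number thought somewhat more likely than a lower one. Compound 3 is estimated at 450 nM, within a range of 120 nM to 2500 nM.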

Compound 3, half-maximal inhibitory concentration: > 10000 nM
Compound 3: only a limit was reported; the forecaster's own chance of this, stated with the estimate: 10%; middle value at least 22-fold (1.34 log units) from the limit.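

In this assay, the pendant phenyl ring proves sensitive to a second kind of group, not only to chloro, with a step of an at least 34-fold higher number from compound 2 to compound 3 (1.53 log units; beyond the scatter). Among the compounds shown here, a single hydroxy in place of hydrogen, para to a large group, is enough to take the compound from a measured number to a limit, which leaves compound 2 with its unsubstituted phenyl as the only compound here with a value that is a number. The step between compound 1 and compound 3 cannot be read, as both values are limits, so no order can be set between the 2-chlorophenyl and the 4-hydroxyphenyl compounds: the limit of > 10000 nM in this assay, at which 2 of the 3 values shown sit.

On these data alone, whether this loss belongs to the hydroxy itself or would follow any group on this carbon stays open, as a methoxy group, a fluoro or an amine in the same place would be needed to tell these apart. How far the number for compound 2 can be improved is also open, as every change to the phenyl ring shown so far ends at a limit.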